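A Dichlorophenyl Group Replaces a Methylthiophene

The source may report more compounds than this note shows. Statements on the series, on what has been measured and on what is new or still open speak of the compounds shown alone.

Compound 1: `O=C(/C(=C\c1ccc(Br)cc1)SCc1ccc(Cl)cc1)c1ccc(Br)cc1`, 1000 nM
Compound 2: `Cc1ccc(S(=O)(=O)/C(=C/c2ccc(C)s2)C(=O)c2ccc(Br)cc2)cc1`, 25000 nM
Compound 3: `Cc1ccc(S/C(=C/c2sccc2C)C(=O)c2ccc(Br)cc2)cc1`, 50000 nM

These numbers come from a functional assay on DU-145 cells (Homo sapiens) for inhibition, read by trypan blue exclusion, with a stated time of 96 h; a higher number here means a weaker inhibitor of growth, a lower number a stronger inhibitor of growth. Compound 3, at 50000 nM, lies within the usual scatter of compound 2, at 25000 nM, so the two cannot be told apart. Compound 1, at 1000 nM, has a much lower number than compound 3, and that gap lies well beyond the scatter.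

The next compound to be tested is compound 4 `Cc1ccc(S/C(=C/c2ccc(Cl)c(Cl)c2)C(=O)c2ccc(Br)cc2)cc1`. It puts 3,4-dichlorophenyl in place of the 3-methylthiophen-2-yl of compound 3, on a double-bonded chain carbon bound to a double-bonded chain carbon (3,4-dichlorophenyl in place of 3-methylthiophen-2-yl on a double-bonded chain carbon bound to a double-bonded chain carbon). For the measured compounds named here, no measured pair isolates this change, so the evidence is indirect. Going by the values given here, compound 1 is the only measured compound with a six-membered aromatic ring of carbon only at that chain carbon, and it gives 1000 nM. However, compound 1 also differs from compound 3 elsewhere, so this is a weak guide.

A drop in the number, beyond the scatter, is therefore expected in this assay, with the estimated step being an 8.3-fold lower number from compound 3 to compound 4 (0.92 log units; beyond the scatter). For compound 4 the estimated value is 6000 nM, with an expected range from 1000 nM to 30000 nM.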

Compound 4, concentration for 50% growth inhibition: 50000 nM
Compound 4: the middle estimate sits 8.3-fold (0.92 log units) below what was measured; measured number above the stated range.
By their numbers in this assay, from the lowest: compound 1; then compounds 2, 3 and 4 (each within the scatter of the next).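

In this assay the step reads no change at the digits printed from compound 3 to compound 4 (within the scatter), the first direct test of a change on a double-bonded chain carbon bound to a double-bonded chain carbon, with the rest of the molecule held fixed. Replacing the five-membered aromatic ring with one sulfur by a six-membered aromatic ring of carbon only, carrying two chlorines, leaves two compounds that cannot be told apart, so in this pair the kind of ring at this carbon does not register in the read-out. No measured information explains why the two groups read alike.

Compound 3 and compound 1 differ in more than one place, so the compounds shown do not settle which of those differences goes with the value of compound 1, 1000 nM. Also open, as far as these compounds go, is how this position would respond to a different kind of group, such as an unsubstituted pyridine ring, a phenyl ring bearing a dimethylamino group, or a phenyl ring bearing a carboxylic acid.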